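Fluoro in Place of Trifluoromethyl on Two Different Cores

The source may report more compounds than this note shows. Statements on the series, on what has been measured and on what is new or still open speak of the compounds shown alone.

Compound 1 `CN1C/C(=C\c2cccnc2)C(=O)/C(=C/c2ccccc2F)C1`: 4470 nM
Compound 2 `CN1C/C(=C\c2cccnc2)C(=O)/C(=C/c2ccccc2C(F)(F)F)C1`: 2910 nM
Compound 3 `O=C1/C(=C/c2cccnc2)CN(S(=O)(=O)c2ccc(C(F)(F)F)cc2)C/C1=C\c1ccccc1F`: 4500 nM

These three compounds were tested in a functional assay on QGY-7703 cells (Homo sapiens) for cytotoxicity, read by MTT assay, with a stated time of 24 h; on this read-out lower numbers stand for stronger inhibition and higher numbers for weaker inhibition. Compound 4 `O=C1/C(=C/c2cccnc2)CN(S(=O)(=O)c2ccc(F)cc2)C/C1=C\c1ccccc1F` has not yet been measured there. It is made from compound 3 by one change, (fluoro in place of trifluoromethyl on an aromatic carbon). The same kind of change has already been made once, from compound 2 to compound 1, (fluoro in place of trifluoromethyl on an aromatic carbon), where it gave a 1.5-fold higher number from compound 2 to compound 1 (0.19 log units; within the scatter). The two places are not identical: in compound 1 the fluoro sits ortho to a large group, whereas in compound 4 it sits para to a large group, so the change is the same kind rather than the same. The difference between the core of compound 2 and the core of compound 3 is not broken down here. Because the earlier step of a 1.5-fold higher number from compound 2 to compound 1 (0.19 log units; within the scatter) stayed within the scatter, the step from compound 3 to compound 4 is expected to be small as well, no change at the digits printed from compound 3 to compound 4 (within the scatter). Compound 4 is therefore estimated at 4500 nM, most likely between 2000 nM and 10000 nM.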

Compound 4, half-maximal inhibitory concentration: 15300 nM
For compound 4 the middle estimate is 3.4-fold (0.53 log units) below the measured one; the whole stated range lies below it.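

Carrying fluoro in place of trifluoromethyl from one core to the other gives two steps that cannot be told apart: the same change on two cores in this assay, a 1.5-fold higher number (0.19 log units; within the scatter) from compound 2 to compound 1 and a 3.4-fold higher number (0.53 log units; beyond the scatter) from compound 3 to compound 4, 2.2-fold (0.35 log units) apart, within the scatter of two such steps. Within the data shown here, the step of a 3.4-fold higher number from compound 3 to compound 4 (0.53 log units; beyond the scatter) is the only one of the pair that clearly exceeds the scatter, but with just two examples, this does not show that the core of compound 3 responds more strongly to the change than the core of compound 2. A separate step, with (4-fluorophenyl)sulfonyl in place of methyl on the ring nitrogen, is a 3.4-fold higher number from compound 1 to compound 4 (0.53 log units; beyond the scatter) and also points to weaker inhibition in this assay, yet it does not show how far either group would shift the result on other cores.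

The compounds shown leave open whether the weaker inhibition of compound 4 is specific to fluoro or would also appear with other groups at that aromatic carbon, such as chloro, methoxy or a nitrile. They also leave open how an amine or a carboxylic acid would behave there.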